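A few compounds are considered here, and "the series" means these few. Any claim that something is new, unique, unknown or untested is made for them only; others in the source may bear on it.

Compound 1 `COc1ncc(-c2cc(OC3CCC3)c3ncnc(C)c3c2)cc1NS(=O)(=O)c1ccc(F)cc1F` is an aryl ether of the shared core carrying a cyclobutyl group on the ether oxygen. In an ADME assay on Caco-2 cells (Homo sapiens) for permeability, read by LC-MS, in the apical to basolateral direction, with a stated time of 90 min (on this read-out lower numbers stand for lower permeability and higher numbers for higher permeability), compound 1 gives 44 10^-6 cm/s, and this sits alongside compound 2 `COc1ncc(-c2cc(OC3CCOCC3)c3ncnc(C)c3c2)cc1NS(=O)(=O)c1ccc(F)cc1F` at 42 10^-6 cm/s and compound 3 `COc1ncc(-c2cc(OC3CCOC(C)(C)C3)c3ncnc(C)c3c2)cc1NS(=O)(=O)c1ccc(F)cc1F` at 31 10^-6 cm/s, all within the scatter of one another. The step to compound 4 `COc1ncc(-c2cc(OC3CCN(C)CC3)c3ncnc(C)c3c2)cc1NS(=O)(=O)c1ccc(F)cc1F` is 1-methylpiperidin-4-yl in place of cyclobutyl on an oxygen on an aromatic ring. The measured steps that bear on it replace the same cyclobutyl by oxygen-containing rings: a 1.0-fold lower number from compound 1 to compound 2 (0.02 log units; within the scatter) and a 1.4-fold lower number from compound 1 to compound 3 (0.15 log units; within the scatter), neither beyond the scatter. Among the measured compounds shown here, no measured step brings a nitrogen into this ring, so the expectation rests on the two oxygen analogues with a wide allowance. Compound 4 is therefore expected to give about 28 10^-6 cm/s, between 10 10^-6 cm/s and 50 10^-6 cm/s, the estimated step being a 1.6-fold lower number from compound 1 to compound 4 (0.20 log units; within the scatter).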

Compound 4, apparent permeability: 4.5 10^-6 cm/s
Beside the measured number, compound 4's estimate is 6.2-fold (0.79 log units) above it; measured number below the stated range.
By their numbers in this assay, from the lowest: compound 4; then compounds 3, 2 and 1 (each within the scatter of the next).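

In this assay, the position on the oxygen, where the oxan-4-yl and 2,2-dimethyloxan-4-yl rings had stayed within the scatter of cyclobutyl, proves sensitive to 1-methylpiperidin-4-yl, with a 9.8-fold lower number from compound 1 to compound 4 (0.99 log units; beyond the scatter), a 9.3-fold lower number from compound 2 to compound 4 (0.97 log units; beyond the scatter) and a 6.9-fold lower number from compound 3 to compound 4 (0.84 log units; beyond the scatter), all beyond the scatter. The six-membered oxan-4-yl ring stays within the scatter of cyclobutyl, so ring size alone does not track this drop. Nothing in the data at hand accounts for it.

From the compounds shown here alone, whether the drop belongs to the ring nitrogen or to its methyl group remains open. So does how a piperidin-4-yl without the methyl, or one with an acetyl group on its nitrogen, would read.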